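The source may hold more compounds than are shown below. What is called first, only, known or untested is meant among the compounds shown, and "the series" means these compounds.

Measured so far in a functional assay on cells (Rhabdomyosarcoma cell, Homo sapiens) for cytotoxicity; on this read-out lower numbers stand for stronger inhibition and higher numbers for weaker inhibition:

Compound 1, `FC(F)(F)c1ccc(C(c2ccccc2)N2CCN(c3ncnc4c3cnn4-c3ccccc3)CC2)cc1` — in this assay compound 1 gives > 25000 nM, which is a limit of the assay and not a number.
Compound 2, `Cc1ccccc1C(c1sccc1C)N1CCN(c2ncnc3c2cnn3-c2ccccc2)CC1` — in this assay compound 2 gives > 25000 nM, likewise a limit.

Compound 1 therefore stands at the limit and nowhere else on the numbers shown; the same holds for the whole set, as the limit of > 25000 nM in this assay, at which 2 of the 2 values shown sit. Among the measured compounds shown here, no step between two measured compounds can be drawn from two limits, so nothing measured tells how far a change at this position moves the read-out.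

Compound 3, `c1ccc(C(c2nccs2)N2CCN(c3ncnc4c3cnn4-c3ccccc3)CC2)cc1`, differs from compound 1 by 1,3-thiazol-2-yl in place of 4-(trifluoromethyl)phenyl on a saturated chain carbon bound to an amine nitrogen in a ring and an aromatic carbon. With compound 1 and compound 2 both sitting at the limit, the expected step is a step that the limit leaves unreadable from compound 1 to compound 3, none beyond the scatter. For compound 3 the estimated value in this assay is 30000 nM, with a range from 8000 nM to 120000 nM, and most likely the assay again reports only a limit.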

Compound 3, half-maximal inhibitory concentration: > 25000 nM
Compound 3: only a limit was reported (the forecaster's own chance of this, stated with the estimate: 80%); the middle value does not contradict the limit.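

No step from compound 1 to compound 3 can be read in this assay, as both values are limits and not numbers: the limit of > 25000 nM in this assay, at which 3 of the 3 values shown sit.

The compounds shown leave open whether 1,3-thiazol-2-yl and 4-(trifluoromethyl)phenyl differ at all in this read-out, and which change to the shared core would bring a value inside the measurable range.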